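The source may report more compounds than this note shows. Statements on the series, on what has been measured and on what is new or still open speak of the compounds shown alone.

Of the compounds shown here, three have so far been tested in a functional assay on HeLa cells (Homo sapiens) for antiproliferative activity, read by MTT assay, with a stated time of 72 h; a higher number here means a weaker inhibitor, a lower number a stronger inhibitor. In that assay, compound 1 `CC(C)N1C(=O)COc2ccc(-c3cnc(Cl)c(NS(=O)(=O)c4ccc(F)cc4)c3)cc21` gives 5380 nM and compound 3 `COc1ncc(-c2ccc3c(c2)N(C2CC2)C(=O)CO3)cc1NS(=O)(=O)c1ccc(F)cc1` gives 6030 nM. Compound 2 `O=C1COc2ccc(-c3cccc(NS(=O)(=O)c4ccc(F)cc4)c3)cc2N1c1ccc(Cl)cc1`, which carries a 4-chlorophenyl group, gives 35000 nM. This is the highest of the three numbers, which makes compound 2 the weakest inhibitor of the set, with both other compounds lower by more than the scatter of repeated measurements.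

Compound 4 `COc1ccc(N2C(=O)COc3ccc(-c4cccc(NS(=O)(=O)c5ccc(F)cc5)c4)cc32)cc1` has not yet been measured. It differs from compound 2 in one place, where methoxy stands in place of chloro on an aromatic carbon, para to a large group, turning 4-chlorophenyl into 4-methoxyphenyl: methoxy in place of chloro on an aromatic carbon.

Going by the values given here, no pair of measured compounds differs by a single change, so the data offer no direct precedent for this swap. Among the compounds with values here, the only anchor is compound 2 at 35000 nM, and compound 4 is expected to stay close to it. In this assay, no step beyond the scatter is expected, with at most a slight drift towards a lower number. The estimate amounts to an expected 1.4-fold lower number from compound 2 to compound 4 (0.15 log units; within the scatter). For compound 4 the estimated value is 25000 nM, with an expected range from 10000 nM to 50000 nM.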

Compound 4, half-maximal inhibitory concentration: 13200 nM
The estimate for compound 4 lay 1.9-fold (0.28 log units) above the measured number; measured number inside the range.
By their numbers in this assay, from the lowest: compounds 1 and 3 (each within the scatter of the next); then compound 4; then compound 2.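

In this assay, methoxy in place of chloro gives a 2.7-fold lower number from compound 2 to compound 4 (0.42 log units; beyond the scatter). Going by these compounds alone, this is the first step in the set that can be read at a single place, and it shows that the group on this aromatic carbon, para to a large group, affects the read-out, since the change goes beyond the scatter. The step is modest and rests on one pair, so it gives a direction for this swap alone and no general trend, and no evidence on hand bears on why it occurs.

On these data alone, it remains open whether other groups on this carbon, such as an amine, a carboxylic acid or a hydroxyl, would move the number further in the same direction or reverse it, and where an unsubstituted phenyl would fall relative to compound 2 and compound 4. As far as these compounds go, it is also open whether methoxy in place of chloro would give a step of similar size elsewhere in the molecule, or on a different substitution pattern of the sulfonamide-bearing ring.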